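A Fluorine on the Benzyl Group of Compound 3

The source may hold more compounds than are shown below. What is called first, only, known or untested is meant among the compounds shown, and "the series" means these compounds.

Measured compounds:
compound 1 `CCn1c(=O)[nH]c(=O)c2[nH]c(-c3cnn(Cc4ccccc4)c3)nc21` — in an assay on HEK293 cells for displacement of a labelled ligand from adenosine receptor A2b (Homo sapiens) (on this read-out higher numbers stand for weaker inhibition and lower numbers for stronger inhibition), compound 1 gives > 6000 nM, a limit of the assay, not a number.
compound 2 `CC(C)Cn1c(=O)[nH]c(=O)c2[nH]c(-c3cnn(Cc4ccccc4)c3)nc21` — compound 2 gives > 6000 nM, again a limit of the assay.
compound 3 `CCCn1c(=O)[nH]c2nc(-c3cnn(Cc4ccccc4)c3)[nH]c2c1=O` — compound 3 gives 13 nM.

In this assay, within the data shown here, compound 3 is therefore the only compound with a measured number; the other two values are limits. Among the measured compounds shown here, the single measured step, from compound 1 to compound 2, a step that the two limits leave unreadable from compound 1 to compound 2, cannot be read because both values sit at the limit of > 6000 nM in this assay, at which 2 of the 3 values shown sit. That step also concerns the chain on the shared core, not the benzyl group.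

Compound 4 `CCCn1c(=O)[nH]c2nc(-c3cnn(Cc4cccc(F)c4)c3)[nH]c2c1=O` is compound 3 with fluoro in place of hydrogen on an aromatic carbon. For the measured compounds named here, no measured step touches this part of the molecule, so nothing among the measured compounds points to a change in either direction. The step from compound 3 to compound 4 is expected to be no change at the digits printed from compound 3 to compound 4 (within the scatter), within the usual scatter. Compound 4 is estimated to give 13 nM in this assay, in a range from 5 nM to 40 nM.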

Compound 4, inhibition constant: 11 nM
Beside the measured number, compound 4's estimate is 1.2-fold (0.07 log units) above it, within the range that was stated.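

Among these compounds, the result is a 1.2-fold lower number from compound 3 to compound 4 (0.07 log units; within the scatter), the first step here that can be read, and it falls on the benzyl group, a part of the molecule that no earlier step touched. In this assay, fluoro in place of hydrogen on this aromatic carbon, meta to a large group, adds one heavy atom, and the two values lie within the scatter of each other, so at this position this small swap leaves the reading where it was. The step from compound 1 to compound 2 still cannot be read: the limit of > 6000 nM in this assay, at which 2 of the 4 values shown sit.

The compounds shown leave open what a methoxy group, a trifluoromethyl group, an amine or a carboxylic acid would do at this same carbon. They also leave open whether fluoro on the other carbons of this ring would read the same way.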